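A few compounds are considered here, and "the series" means these few. Any claim that something is new, unique, unknown or untested is made for them only; others in the source may bear on it.

In a functional assay on MCF7 cells (Homo sapiens) for antiproliferative activity, read by MTT assay, with a stated time of 24 h (on this read-out higher numbers stand for weaker inhibition and lower numbers for stronger inhibition), the measured compounds read as follows:

Compound 1 `CCCC(O)(C#Cc1ccc(C(CC)(CC)C2=CN(CC)C(C(=O)NCCN(CC)CC)C2)cc1C)CCC` gives 1290 nM
Compound 2 `CCN(CC)CCNC(=O)C1CC=C(C(CC)(CC)c2ccc(C#CC(C)(C)O)c(C)c2)N1CC` gives 1490 nM

Compound 2 at 1490 nM stands within the scatter of compound 1 at 1290 nM and the two cannot be ranked on these numbers.

Compound 3 `CCCC(O)(C#Cc1ccc(C(CC)(CC)C2=CCC(C(=O)NCCN(CC)CC)N2CC)cc1C)CCC` is not yet measured. In going from compound 2 to compound 3 the 1-hydroxy-1-methylethyl group leaves a triple-bonded carbon and the change is a group of 8 heavy atoms (7 carbon, 1 oxygen; no ring) in place of a group of 4 heavy atoms (3 carbon, 1 oxygen; no ring), on a triple-bonded carbon at that place. Among the compounds with values here, no measured step shows this change on its own. Compound 1 also carries the entering group, and compound 1 gives 1290 nM in this assay so no effect beyond the scatter is expected, in either direction. The expected step of a 1.1-fold lower number from compound 2 to compound 3 (0.06 log units; within the scatter) is therefore small. Compound 3 is estimated at 1300 nM with an expected range from 600 nM to 2800 nM in this assay for now.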

Compound 3, half-maximal inhibitory concentration: 1360 nM
For compound 3 the middle estimate is 1.0-fold (0.02 log units) below the measured one; the measured number falls inside the stated range.
By their numbers in this assay, from the lowest: compounds 1, 3 and 2 (each within the scatter of the next).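

In this assay, the exchange of the 1-hydroxy-1-methylethyl group for the group of 8 heavy atoms (7 carbon, 1 oxygen; no ring), on a triple-bonded carbon, gives a 1.1-fold lower number from compound 2 to compound 3 (0.04 log units; within the scatter). Within the data shown here, this is the first reading of that change on its own: the added heavy atoms leave compound 3 unranked against compound 2, and the counts of hydrogen-bond donors and acceptors are the same in both groups. Nothing on hand explains why the read-out holds across this change.

On these data alone, both groups tested here carry oxygen and no ring, so it remains open how an amine, a carboxylic acid or a plain hydrocarbon chain on the same triple-bonded carbon would read in this assay. As far as these compounds go, whether this tolerance holds with any other part of the shared core changed is also open.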